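Dibenzylurea with a chloro-methylphenyl group replacing the trimethylphenyl

The compounds below may be only part of what the source reports. "The series", "measured", "known", "first", "only" and "open" are said of these compounds alone.

Compound 1, `CCCCCCCN(CCCCCCC)C(=O)Nc1ccc(C)cc1C`, gives 0.26 ug/mL in an assay on isolated protein for inhibition of sterol O-acyltransferase 1 (Rattus norvegicus); on this read-out lower numbers stand for stronger inhibition and higher numbers for weaker inhibition. Compound 2, `Cc1cc(C)c(NC(=O)N(Cc2ccccc2)Cc2ccccc2)cc1C`, gives 0.16 ug/mL in the same assay. Among the compounds with values here, of the two numbers known so far, compound 2 has the smaller one, but its gap to compound 1 lies within the scatter of repeated measurements, so the two cannot be told apart on this evidence. Within the data shown here, no step between two measured compounds that differ in a single place is available. Compound 3, `Cc1c(Cl)cccc1NC(=O)N(Cc1ccccc1)Cc1ccccc1`, differs from compound 2 by 3-chloro-2-methylphenyl in place of 2,4,5-trimethylphenyl on an amide-type nitrogen. Among the measured compounds shown here, with no comparable step measured, the expected step from compound 2 to compound 3 is a 1.6-fold higher number from compound 2 to compound 3 (0.19 log units; within the scatter), which is not expected to reach beyond the scatter. Compound 3 is therefore estimated at 0.25 ug/mL, with a likely range from 0.08 ug/mL to 0.8 ug/mL.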

Compound 3, half-maximal inhibitory concentration: 3.06 ug/mL
The estimate for compound 3 lay 12-fold (1.09 log units) below the measured number, and the stated range ends below it.
By their numbers in this assay, from the lowest: compounds 2 and 1 (each within the scatter of the next); then compound 3.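

In this assay, the group on the amide-type nitrogen turns out to matter strongly: 3-chloro-2-methylphenyl in place of 2,4,5-trimethylphenyl gives a 19-fold higher number from compound 2 to compound 3 (1.28 log units; beyond the scatter), with the rest of the molecule unchanged. Compound 1 and compound 2 differ in more than one place, so they could not isolate this position, whereas this single change does. The two groups have the same counts of aromatic rings, hydrogen-bond donors and acceptors and the same lack of net charge, and no measurement at hand bears on what lies behind the step.

The compounds shown leave open whether the entering chlorine or the loss and shift of the methyl groups carries the step. They also leave open how an aryl group bearing a methoxy group or an amine would fare at this nitrogen.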